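The source may report more compounds than this note shows. Statements on the series, on what has been measured and on what is new or still open speak of the compounds shown alone.

Measured so far in a functional assay on K562 cells (Homo sapiens) for inhibition; a lower number here means a stronger inhibitor of growth, a higher number a weaker inhibitor of growth:
- compound 1 `NS(=O)(=O)c1ccc(/C=C/c2ccc(O)c(O)c2)cc1` gives 35300 nM
- compound 2 `COc1cccc(/C=C/c2ccc(S(N)(=O)=O)cc2)c1` gives 20600 nM
- compound 3 `NS(=O)(=O)c1ccc(/C=C/c2ccc(F)cc2)cc1` gives 14900 nM

Compound 3, at 14900 nM on this scale, stands level with compound 2, as the two values lie within the usual scatter of each other. Compound 1 has a higher number than compound 3, and that gap lies beyond the scatter.

The next compound is compound 4 `NS(=O)(=O)c1ccc(/C=C/c2ccc(O)cc2)cc1` and it has hydroxy in place of fluoro on an aromatic carbon, para to a large group hydroxy in place of fluoro on an aromatic carbon with the rest of compound 3 unchanged. Within the data shown here, no two measured compounds differ in one place only, so no measured step shows this swap directly. The only hint is weak: compound 1 also carries hydroxy groups and gives 35300 nM in this assay on a differently substituted ring. The expected change is a 1.5-fold higher number from compound 3 to compound 4 (0.17 log units; within the scatter) and it points to a slightly weaker inhibitor, quite possibly no larger than the scatter. For compound 4 the estimated value is 22000 nM with an expected range from 9000 nM to 50000 nM in this read-out.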

Compound 4, concentration for 50% growth inhibition: 24900 nM
Compound 4: middle estimate off by 1.1-fold (0.05 log units), on the low side; the range from low to high includes it.
By their numbers in this assay, from the lowest: compounds 3, 2, 4 and 1 (each within the scatter of the next, the first and the last beyond it).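

In this assay, the swap of hydroxy in place of fluoro on an aromatic carbon, para to a large group, can now be read directly (a 1.7-fold higher number from compound 3 to compound 4 (0.22 log units; within the scatter)), so at this place these two small groups cannot be told apart by this read-out. The second single change, hydrogen in place of hydroxy on an aromatic carbon, also stays small (a 1.4-fold lower number from compound 1 to compound 4 (0.15 log units; within the scatter)), so the extra hydroxy of compound 1 has no clear effect on the number either. Neither step can be explained from what is available here, as no independent measurement bears on why the numbers fall where they do.

Still open, going by these compounds, is whether an amine, a carboxylic acid or a longer chain at this same place would give a step beyond the scatter. Only fluoro and hydroxy have been compared here, so these results cannot be extended to other groups.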